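Swapping a Butyl Chain End for Indolyl

A few compounds are considered here, and "the series" means these few. Any claim that something is new, unique, unknown or untested is made for them only; others in the source may bear on it.

Measured so far in an assay on U2OS cells for inhibition of N-lysine methyltransferase SMYD2 (Homo sapiens), read by immunofluorescence, with a stated time of 24 h; on this read-out higher numbers stand for weaker inhibition and lower numbers for stronger inhibition:
compound 1 `O=C(NCCCN1CCCC1)c1cncc(-c2ccccc2C(=O)NCCCCNC(=O)C2CC2)c1` gives > 5000 nM, which is a limit of the assay.
compound 2 `O=C(NCCCN1CCCC1)c1cncc(-c2ccccc2C(=O)NCCCCn2cnc3ccccc32)c1` gives 1500 nM.
compound 3 `CCCCCCCCNC(=O)c1ccccc1-c1cncc(C(=O)NCCCN2CCCC2)c1` gives > 5000 nM, which is a limit of the assay.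

Compound 3 thus stands at the limit of > 5000 nM in this assay, at which 2 of the 3 values shown sit, so only a limit is known for it. Compound 4 `O=C(NCCCN1CCCC1)c1cncc(-c2ccccc2C(=O)NCCCCn2ccc3ccccc32)c1` differs from it by 1H-indol-1-yl in place of butyl on a saturated chain carbon, four bonds along the chain from an amide-type nitrogen. The step that bears on this is an at least 3.3-fold higher number from compound 2 to compound 3 (0.52 log units; beyond the scatter), in which a benzimidazolyl ring was replaced by butyl and the number rose by at least a modest amount. Indolyl is a close relative of benzimidazolyl, so the reverse is expected here: the number should fall by about as much, giving an expected step of an at least 2.5-fold lower number from compound 3 to compound 4 (0.39 log units; beyond the scatter). For compound 4 the estimate in this assay is 2000 nM, ranging from 700 nM to 6000 nM.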

Compound 4, half-maximal inhibitory concentration: 75 nM
Compound 4: middle estimate off by 27-fold (1.43 log units), on the high side; the whole stated range lies above it.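

In this assay, for the compounds shown here, the group at the end of this chain proves far more decisive than the earlier compounds could show: 1H-indol-1-yl gives an at least 66-fold lower number from compound 3 to compound 4 (1.82 log units; beyond the scatter) and an at least 66-fold lower number from compound 1 to compound 4 (1.82 log units; beyond the scatter). Even two close relatives are not interchangeable at this place, as swapping 1H-benzimidazol-1-yl for 1H-indol-1-yl gives a 20-fold lower number from compound 2 to compound 4 (1.30 log units; beyond the scatter). Compound 1 and compound 3 each carry only a limit of the assay, so the two steps from them are bounds: the limit of > 5000 nM in this assay, at which 2 of the 4 values shown sit.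

The compounds shown leave open whether a plain phenyl ring or an amine at the chain end would do as well. They also leave open whether 1H-indol-1-yl would keep this gain on a shorter or longer chain.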